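Aryl replacement at the shared core: compound 2 to compound 3

The compounds below may be only part of what the source reports. "The series", "measured", "known", "first", "only" and "open" are said of these compounds alone.

Going by the values given here, compound 2 `Cc1ccc(-c2cncc(Cl)c2N2CCC3(CCNC3=O)CC2)s1` holds the lowest of the two numbers measured so far in a functional assay on MV4-11 cells (Homo sapiens) for inhibition, read by resazurin assay, with a stated time of 72 h (a higher number here means a weaker inhibitor of growth, a lower number a stronger inhibitor of growth), where compound 2 gives 650 nM. The nearest point is compound 1 `CCOCOCc1ccc(-c2cncc(Cl)c2N2CCC3(CCNC3=O)CC2)o1`; in this assay compound 1 gives 2970 nM, and the gap between these two values lies beyond the scatter of the method. Among the compounds with values here, no two measured compounds differ in only one place, so the data give no single-change step to lean on.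

Compound 3 `O=C1NCCC12CCN(c1c(Cl)cncc1-c1cnn(C(F)F)c1)CC2` is not yet measured. It differs from compound 2 in one place: 1-(difluoromethyl)-1H-pyrazol-4-yl in place of 5-methylthiophen-2-yl on an aromatic carbon. The chloro group and the rest of the shared core are untouched.

Within the data shown here, with no measured step for a replacement of this kind, the expectation rests on the two values above alone. A modest step toward a higher number is expected, though a result within the scatter of compound 2 cannot be excluded. The expected step is a 2.3-fold higher number from compound 2 to compound 3 (0.36 log units; beyond the scatter). For compound 3 in this assay the estimated value is 1500 nM, with a range from 400 nM to 6000 nM.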

Compound 3, concentration for 50% growth inhibition: 6140 nM
Beside the measured number, compound 3's estimate is 4.1-fold (0.61 log units) below it, outside the stated range (above it).
By their numbers in this assay, from the lowest: compound 2; then compound 1; then compound 3.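

In this assay the replacement of 5-methylthiophen-2-yl by 1-(difluoromethyl)-1H-pyrazol-4-yl gives a 9.4-fold higher number from compound 2 to compound 3 (0.98 log units; beyond the scatter) and so provides the only single-change step shown in the series. The aromatic carbon two atoms from the ring nitrogen and ortho to a large group is therefore not indifferent to which five-membered aromatic ring it carries, even with the chloro group and the rest of the shared core untouched. Nothing measured bears on why the step has this size.

The change alters the ring and its substituent together, so the compounds shown leave open which of the two carries the step; a 1-methyl-1H-pyrazol-4-yl or an unsubstituted thiophen-2-yl on the same carbon would separate them. Also open, from the compounds shown here alone, is whether a step of this size would persist with a nitrile in place of the chloro group, and compound 1 cannot address either question, as it differs from compound 2 and compound 3 in more than one place.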